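The source may hold more compounds than are shown below. What is called first, only, known or untested is meant among the compounds shown, and "the series" means these compounds.

Two urea-linked compounds have been measured in a functional assay on CHO cells for antagonist activity at sphingosine 1-phosphate receptor 2 (Homo sapiens), read by scintillation counting and GTPgammaS binding, with a stated time of 4 h, in the presence of a further agent that is not named here; a lower number here means a stronger inhibitor, a higher number a weaker inhibitor. Compound 1 `CCOc1cc(NC(=O)NCc2cc(C)c(-c3cn(C)nc3C(F)(F)F)nn2)cc(C#N)n1` gives 35 nM, and compound 2 `CCOc1nc(Cl)cc(NC(=O)NCc2cc(C)c(-c3cn(C)nc3C(F)(F)F)nn2)c1C` gives 15 nM. The step of a 2.3-fold lower number from compound 1 to compound 2 (0.37 log units; beyond the scatter) is modest, and compound 2 therefore holds the lower of the two numbers. Compound 3 `CCOc1nc(C#N)cc(NC(=O)NCc2cc(C)c(-c3cn(C)nc3C(F)(F)F)nn2)c1C` differs from compound 2 by cyano in place of chloro on an aromatic carbon, a cyano in place of chloro on an aromatic carbon. Going by the values given here, no measured step swaps these two groups directly; compound 1 also carries a cyano group but differs from compound 2 in more than one place, so it offers only a rough guide. The expected step of a 1.3-fold higher number from compound 2 to compound 3 (0.12 log units; within the scatter) should stay within the scatter. Compound 3 is therefore estimated at 20 nM, within 7 nM to 60 nM.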

Compound 3, half-maximal inhibitory concentration: 24 nM
The estimate for compound 3 lay 1.2-fold (0.08 log units) below the measured number, and the stated range covers the measured number.
By their numbers in this assay, from the lowest: compounds 2, 3 and 1 (each within the scatter of the next, the first and the last beyond it).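

On the aromatic carbon next to the ring nitrogen, cyano and chloro cannot be told apart in this series (a 1.6-fold higher number from compound 2 to compound 3 (0.20 log units; within the scatter)). Compound 3 also shows the methyl group on its own, and that single change likewise stays within the scatter (a 1.5-fold lower number from compound 1 to compound 3 (0.16 log units; within the scatter)). Going by these compounds alone, only the step from compound 1 to compound 2, which combines both changes, goes beyond it. Going by these compounds, whether an amine, a carboxylic acid or a longer chain would be accepted on that aromatic carbon stays open. Nothing shown here explains these small steps.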